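A few compounds are considered here, and "the series" means these few. Any claim that something is new, unique, unknown or untested is made for them only; others in the source may bear on it.

In an ADME assay on HEK293 cells (Homo sapiens) for cytotoxicity, with a stated time of 72 h (on this read-out higher numbers stand for an effect only at larger amounts of compound and lower numbers for an effect already at smaller amounts), compound 1 (`C=C[C@@](C)(/C=C/c1ccc(OS(=O)(=O)C(F)(F)F)cc1)CCC=C(C)C`) gives > 36600 nM as a limit. Compound 2 (`C=C[C@@](C)(/C=C/c1ccc(Nc2cc(F)c(F)c(F)c2)cc1)CCC=C(C)C`) gives > 36600 nM as a limit too. Compound 3 (`C=C[C@@](C)(/C=C/c1ccc(Nc2ccc(Cl)cc2)cc1)CCC=C(C)C`) gives > 36600 nM as a limit as well, so it stands without a number of its own. Compound 4 (`C=C[C@@](C)(/C=C/c1ccc(Nc2ccc(Cl)c(Cl)c2)cc1)CCC=C(C)C`) differs from it by chloro in place of hydrogen on an aromatic carbon, which turns 4-chlorophenyl to 3,4-dichlorophenyl. For the measured compounds named here, two measured steps bear on this, one (a step that the two limits leave unreadable from compound 2 to compound 3) and the other (a step that the two limits leave unreadable from compound 1 to compound 3), and neither gives a size. Going by the values given here, all that remains is the limit of > 36600 nM in this assay, at which 3 of the 3 values shown sit, and so no step of known size or direction is expected (a number no higher from compound 3 to compound 4 (the limit leaves the size open)). For compound 4 the estimated value is 36600 nM with an expected range from 15000 nM to 73000 nM in this read-out.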

Compound 4, half-maximal effective concentration: > 36600 nM
Compound 4: only a limit was reported; the forecaster's own chance of this, stated with the estimate: 75%; the middle value sits exactly at the limit.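

No new step can be read for compound 4, since it, like compound 1, compound 2 and compound 3, is reported only as a limit: the limit of > 36600 nM in this assay, at which 4 of the 4 values shown sit. The compounds shown leave open what actual value any of the four would give in this assay, and so whether they differ at all.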